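A few compounds are considered here, and "the series" means these few. Any claim that something is new, unique, unknown or untested is made for them only; others in the source may bear on it.

Compound 3 `CCOC(=O)CCCCCOc1cccc(CN(C(=O)c2ccc(-c3cccc4ccccc34)cc2)C(C)C)c1` stands in an ADME assay on BJ cells (Homo sapiens) for cytotoxicity, read by CellTiter-Glo and resazurin assay, with a stated time of 72 h (on this read-out higher numbers stand for an effect only at larger amounts of compound and lower numbers for an effect already at smaller amounts), at a limit of the assay, > 26000 nM, as recorded in the limit of > 26000 nM in this assay, at which 2 of the 3 values shown sit. Compound 1 `CC(C)N(Cc1cccc(OCCCCCC(=O)O)c1)C(=O)c1ccc(-c2cccc3ccccc23)cc1` gives < 1.3 nM, also a limit of the assay, recorded in the limit of < 1.3 nM in this assay, at which 1 of the 3 values shown sits. Compound 2 `CC(C)N(Cc1cccc(OCCCCCC(=O)O)c1)C(=O)c1ccc(-c2cccc([N+](=O)[O-])c2)cc1` sits at a limit as well, > 26000 nM. Both measured steps start from compound 1: an at least 20000-fold higher number from compound 1 to compound 2 (4.30 log units; beyond the scatter) and an at least 20000-fold higher number from compound 1 to compound 3 (4.30 log units; beyond the scatter). Compound 4 `CCOC(=O)CCCCCOc1cccc(CN(C(=O)c2ccc(-c3cccc(-c4ccccc4)c3)cc2)C(C)C)c1` differs from compound 3 by 3-phenylphenyl in place of naphthalen-1-yl on an aromatic carbon. Neither measured step covers this exchange of aryl groups on an ethyl ester; the ethyl ester of compound 3 is kept in compound 4, and compound 2 likewise sits at the limit after an aryl exchange from compound 1. No step beyond the scatter is expected, so compound 4 is expected at 30000 nM, within 8000 nM to 100000 nM, corresponding to a step that the limit leaves unreadable from compound 3 to compound 4.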

Compound 4, half-maximal effective concentration: > 26000 nM
Compound 4 was reported as a limit (the forecaster's own chance of this, stated with the estimate: 80%); the middle value is on the limit's open side.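

Compound 3 and compound 4 both sit at a limit, so no step between them can be read: the limit of > 26000 nM in this assay, at which 3 of the 4 values shown sit.

Left open is whether 3-phenylphenyl in place of naphthalen-1-yl changes this read-out at all on the ethyl ester.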